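This account rests on a few compounds, and the source may have more. Where it says the series, first, only, none or still open, it means among the compounds named here.

Three compounds that share one core were tested in an ADME assay on Vero cells (Chlorocebus sabaeus) for cytotoxicity, read by neutral red uptake, tested at 1575 ug/mL; on this read-out lower numbers stand for a stronger effect and higher numbers for a weaker effect at the one concentration tested. Compound 1 `O=C1CSC(c2ccc(Cl)cc2)N1CCN1CCCCC1` gives 13%. Going by the values given here, compound 2 `O=C1CSC(c2ccccc2Cl)N1CCN1CCCCC1` gives 16% in this assay, and the single step between two measured compounds, a number 3 percentage points higher from compound 1 to compound 2 (within the scatter), exchanged one chlorophenyl for another without leaving the scatter. Compound 3 `COc1cccc(C2SCC(=O)N2CCN2CCCCC2)c1` gives 11% in this assay, which is the lowest of the three numbers, yet its gaps to compound 1 and to compound 2 both lie within the scatter, so the three cannot be ranked against each other.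

Compound 4 `O=C1CSC(c2cccc(O)c2)N1CCN1CCCCC1` has not yet been measured. It differs from compound 3 in one place: hydrogen in place of methyl on an oxygen on an aromatic ring. Among the compounds with values here, no measured step touches the group on this oxygen. Within the data shown here, the only measured step, a number 3 percentage points higher from compound 1 to compound 2 (within the scatter), concerned the group on the saturated ring carbon and stayed within the scatter, and all three measured numbers sit close together. Among the measured compounds shown here, the change from methoxy to hydroxy therefore has no direct precedent here, and nothing in the data points to a shift beyond the scatter. For compound 4 the step of a number 1 percentage points higher from compound 3 to compound 4 (within the scatter) is expected to stay within the scatter. Compound 4 is estimated to give 12% in this assay, within a range from 4% to 22%.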

Compound 4, a percentage reported as activity, at one concentration (the size of the read-out at that concentration, not a potency): 13%
The estimate for compound 4 lay 1 percentage points below the measured number, within the range that was stated.
By their numbers in this assay, from the lowest: compounds 3, 1, 4 and 2 (each within the scatter of the next).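

In this assay the oxygen on the aromatic ring now has a measured step of its own: going from methoxy to hydroxy gives a number 2 percentage points higher from compound 3 to compound 4 (within the scatter) and so leaves the read-out inside the scatter once the methyl on this oxygen gives way to hydrogen. The group on the saturated ring carbon gains two further steps, a number 3 percentage points lower from compound 2 to compound 4 (within the scatter) and no change at the digits printed from compound 1 to compound 4 (within the scatter) and with them 3-hydroxyphenyl cannot be told apart from either chlorophenyl, so every step measured so far in this small set stays within the scatter. Nothing shown explains why these numbers lie so close together.

The compounds shown leave open whether a larger group on this oxygen, such as a longer chain like butoxy or a chain ending in a carboxylic acid or an amine, would carry the number beyond the scatter. They also leave open how these compounds would compare at other concentrations, since a read-out at one concentration gives the size of an effect there and not a potency.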